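The source may report more compounds than this note shows. Statements on the series, on what has been measured and on what is new or still open speak of the compounds shown alone.

- Compound 1 `O=S(=O)(NCCNC(=S)Nc1cccc(Cl)c1)c1ccc(-c2ccccc2OCc2ccccc2)s1`: > 50000 nM (a limit)
- Compound 2 `O=C(NCCNS(=O)(=O)c1ccc(-c2ccccc2Oc2ccc([N+](=O)[O-])c([N+](=O)[O-])c2)s1)Nc1cc(Cl)cc(Cl)c1`: 2100 nM
- Compound 3 `O=[N+]([O-])c1cccc(NC(=S)NCCNS(=O)(=O)c2ccc(-c3ccccc3OCc3ccccc3)s2)c1`: 11600 nM

In a functional assay on RS4-11 cells (Homo sapiens) for inhibition, read by CCK-8 assay, with a stated time of 48 h (on this read-out higher numbers stand for weaker inhibition and lower numbers for stronger inhibition), compound 3 gives 11600 nM, the higher of the two actual numbers. Compound 2 gives a lower number, 2100 nM. Compound 1 gives > 50000 nM, which is a limit and not a number.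

The next compound, compound 4 `O=C(NCCNS(=O)(=O)c1ccc(-c2ccccc2OCc2ccccc2)s1)Nc1cc(Cl)cc(Cl)c1`, has not yet been measured. It differs from compound 3 as follows: a group of 11 heavy atoms (7 carbon, 1 nitrogen, 1 oxygen, 2 chlorine; one six-membered aromatic ring of carbon only) in place of a group of 12 heavy atoms (7 carbon, 2 nitrogen, 2 oxygen, 1 sulfur; one six-membered aromatic ring of carbon only), on an amine nitrogen. The entering group, (3,5-dichlorophenyl)carbamoyl, sits on an amine nitrogen.

Two pieces of evidence bear on this change, and they pull in opposite directions. Among the compounds with values here, the only measured step, an at least 4.3-fold lower number from compound 1 to compound 3 (0.63 log units; beyond the scatter), puts nitro in place of chloro on an aromatic carbon and lies beyond the scatter. Compound 4 gives up the nitro and carries chloro, so this step points towards weaker inhibition. Against that, compound 2 carries the same (3,5-dichlorophenyl)carbamoyl group and gives 2100 nM, which points towards stronger inhibition.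

With the two signals roughly offsetting each other, only a small change is expected, a 1.5-fold lower number from compound 3 to compound 4 (0.16 log units; within the scatter). The estimate for compound 4 is 8000 nM, with an expected range of 2000 nM to 32000 nM.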

Compound 4, half-maximal inhibitory concentration: > 20000 nM
Compound 4 ended at the assay's limit; the forecaster's own chance of this, stated with the estimate: 15%; middle value at least 2.5-fold (0.39 log units) from the limit.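

On this amine nitrogen, putting (3,5-dichlorophenyl)carbamoyl in place of the group carrying the nitro-substituted ring gives an at least 1.7-fold higher number from compound 3 to compound 4 (0.23 log units; that floor lies within the scatter) in this assay, so nothing here shows that the entering group strengthens inhibition when the oxygen carries benzyl. The same carbamoyl group is present in compound 2, and benzyl in place of 3,4-dinitrophenyl on an oxygen on an aromatic ring gives an at least 9.5-fold higher number from compound 2 to compound 4 (0.97 log units; beyond the scatter), which shows that the carbamoyl group alone does not bring the stronger inhibition of compound 2. The result for compound 4 is a limit and not a number, so its true distance from compound 3 cannot be told: the limit of > 20000 nM in this assay, at which 1 of the 4 values shown sits.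

From the compounds shown here alone, the step between compound 1 and compound 4 cannot be read, since both results are limits: the limit of > 50000 nM in this assay, at which 1 of the 4 values shown sits. Still open is whether 3,4-dinitrophenyl on that oxygen would also lower the number when paired with the group carried by compound 3, and what a smaller group such as methyl on that oxygen, or a longer chain in the linker, would do.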